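The source may report more compounds than this note shows. Statements on the series, on what has been measured and on what is new or still open speak of the compounds shown alone.

Compound 1 `Nc1sc(-c2ccc(Cl)cc2)c(-c2ccc(Cl)cc2)c1C(=O)NC1CCC(O)CC1` has a free amine on the shared core and an amide whose nitrogen carries a 4-hydroxycyclohexyl group. Among the compounds with values here, in a functional assay on A549 cells (Homo sapiens) for inhibition, read by sulforhodamine B assay, with a stated time of 72 h (on this read-out higher numbers stand for weaker inhibition and lower numbers for stronger inhibition), compound 1 gives 250 nM, the lower of the two numbers measured so far. Within the data shown here, compound 2 `CC(=O)Nc1sc(-c2ccc(Cl)cc2)c(-c2ccc(Cl)cc2)c1C(=O)N1CCCCC1` differs from compound 1 in more than one place, and in this assay compound 2 gives 6010 nM; the two values show only that compound 2 sits far higher, well beyond the scatter. Compound 3 `Nc1sc(-c2ccc(Cl)cc2)c(-c2ccc(Cl)cc2)c1C(=O)NC1CC1` is the compound now to be measured. Its change from compound 1 is cyclopropyl in place of 4-hydroxycyclohexyl on an amide-type nitrogen. The entering group brings no hydrogen-bond donor or acceptor, whereas the leaving group had one of each. Among the measured compounds shown here, no measured pair isolates this change, so the expected step from compound 1 to compound 3 is a modest weakening, a 3.2-fold higher number from compound 1 to compound 3 (0.51 log units; beyond the scatter), probably beyond the scatter. Compound 3 is therefore estimated at 800 nM, within a range from 250 nM to 3000 nM.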

Compound 3, half-maximal inhibitory concentration: 1950 nM
Compound 3: the middle estimate sits 2.4-fold (0.39 log units) below what was measured; low and high end bracket the measured number.
By their numbers in this assay, from the lowest: compound 1; then compound 3; then compound 2.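

Within the data shown here, compound 1 and compound 3 are the first pair here that differ in one place, so the group on the amide-type nitrogen can be read on its own. In this assay, cyclopropyl in place of 4-hydroxycyclohexyl gives a 7.8-fold higher number from compound 1 to compound 3 (0.89 log units; beyond the scatter), so what sits on this nitrogen clearly changes the number. The swap alters two things at once, since a six-membered ring becomes a three-membered ring and the hydrogen-bond donor and acceptor of the leaving group are gone, and no measurement at hand explains the rise.

The compounds shown leave open which of these two differences carries the step, and a plain cyclohexyl on this nitrogen would separate them. From the compounds shown here alone, how an amine or a carboxylic acid on that ring would read also remains open.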